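The source may report more compounds than this note shows. Statements on the series, on what has been measured and on what is new or still open speak of the compounds shown alone.

Among the measured compounds shown here, in a functional assay on HCT-15 cells (Homo sapiens) (a higher number here means that more compound is needed for the effect, a lower number that less compound is needed), three compounds have numbers so far: compound 1 `COc1cc(C2OC(c3ccc(N)c(C)c3)=NN2C(C)=O)cc(OC)c1OC` gives 0.042 uM, compound 2 `COc1cc(C2OC(c3ccc(N(C)C)cc3)=NN2C(C)=O)cc(OC)c1OC` gives 0.033 uM and compound 3 `COc1cc(C2OC(c3ccc(N(C)C)cc3)=NN2C=O)cc(OC)c1OC` gives 0.096 uM. Compound 3 therefore holds the highest of the three numbers. The next compound to be measured is compound 4 `CCOC(=O)C(=O)N1N=C(c2ccc(N(C)C)cc2)OC1c1cc(OC)c(OC)c(OC)c1`. It has ethoxycarbonyl in place of hydrogen on a carbonyl carbon whose other neighbour is an amide-type nitrogen in a ring: ethoxycarbonyl in place of hydrogen on a carbonyl carbon.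

Of the measured steps, a 1.3-fold lower number from compound 1 to compound 2 (0.10 log units; within the scatter) concerns a different place, the group on a carbon with a double bond to nitrogen, so it gives little guidance here. The relevant step is a 2.9-fold higher number from compound 2 to compound 3 (0.46 log units; beyond the scatter), made on the same carbonyl carbon, with hydrogen in place of methyl. Read in reverse, this suggests that replacing the hydrogen of compound 3 may lower the number. For the measured compounds named here, it is a single modest step, however, and no measured compound carries ethoxycarbonyl at this place, so only a small move in that direction is expected, probably not beyond the scatter.

In this assay the expected step is a 1.6-fold lower number from compound 3 to compound 4 (0.20 log units; within the scatter). The estimate for compound 4 is 0.06 uM, with an expected range from 0.02 uM to 0.2 uM.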

Compound 4, concentration for half-maximal effect: 45 uM
For compound 4 the middle estimate is 750-fold (2.88 log units) below the measured one; the whole stated range lies below it.
By their numbers in this assay, from the lowest: compounds 2 and 1 (each within the scatter of the next); then compound 3; then compound 4.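

Within this assay, this carbonyl carbon proves far less forgiving than the earlier compounds suggested: the only prior change here was a 2.9-fold higher number from compound 2 to compound 3 (0.46 log units; beyond the scatter) and so gave no sign of a step on the scale of a 470-fold higher number from compound 3 to compound 4 (2.67 log units; beyond the scatter) and a 1400-fold higher number from compound 2 to compound 4 (3.13 log units; beyond the scatter) now seen with ethoxycarbonyl. The direction also fails to carry over, since methyl gives a lower number than hydrogen at this place while ethoxycarbonyl gives a much higher one, so the three groups do not fall on one simple trend from the hydrogen compound. No measurement shown here accounts for the loss, and the size of the step is therefore recorded without a cause.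

Still open, as far as these compounds go, is which part of the entering group carries the effect: a longer chain such as propyl, an amine or a carboxylic acid on this carbonyl carbon would help separate the ester from the rest of the group. Also open, from the compounds shown here alone, is whether ethoxycarbonyl has the same effect when the 4-amino-3-methylphenyl group of compound 1 replaces the 4-(dimethylamino)phenyl group.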